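Swapping an Oxygen Linker for Sulfur in a Diamine Series

This account rests on a few compounds, and the source may have more. Where it says the series, first, only, none or still open, it means among the compounds named here.

Three compounds share a core carrying two amino groups and a phenyl group, and each has been tested in a functional assay on SR cells (Homo sapiens) for inhibition, read by sulforhodamine B assay, with a stated time of 48 h; on this read-out higher numbers stand for weaker inhibition of growth and lower numbers for stronger inhibition of growth. Compound 1 `Nc1cc(N)c2nc(-c3ccccc3)c(Oc3ccc(Cl)c(Cl)c3)nc2c1` gives 24000 nM in this assay. Compound 3 `COc1ccc(CNc2nc3cc(N)cc(N)c3nc2-c2ccccc2)cc1OC` gives 18200 nM, and compound 2 `CCOC(=O)[C@H](CCC(=O)O)NC(=O)c1ccc(CNc2nc3cc(N)cc(N)c3nc2-c2ccccc2)cc1` gives 5750 nM. Among these three numbers compound 1 has the highest one; compound 3 sits within the usual scatter of it, while compound 2 lies beyond the scatter and therefore shows the stronger inhibition of growth of the set.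

Compound 4 `Nc1cc(N)c2nc(-c3ccccc3)c(Sc3ccc(Cl)c(Cl)c3)nc2c1` has not yet been measured. It differs from compound 1 in one place: (3,4-dichlorophenyl)sulfanyl in place of 3,4-dichlorophenoxy on an aromatic carbon. The two groups are the same size and share the same count of hydrogen-bond donors and acceptors; only the linking atom changes. For the measured compounds named here, no measured pair in this set shows such a change, so its effect can only be guessed. Because compound 1 gives 24000 nM and compound 3, with a different group in the same region, stays within the scatter of it, a small step is expected. The step from compound 1 to compound 4 is estimated at a 1.6-fold lower number from compound 1 to compound 4 (0.20 log units; within the scatter) in this assay, toward a somewhat lower number, though it may fall within the scatter. Compound 4 is therefore expected to give about 15000 nM, with a likely range from 5000 nM to 45000 nM.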

Compound 4, concentration for total growth inhibition: 35500 nM
Beside the measured number, compound 4's estimate is 2.4-fold (0.37 log units) below it; measured number inside the range.
By their numbers in this assay, from the lowest: compound 2; then compounds 3, 1 and 4 (each within the scatter of the next).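

In this assay, for the compounds shown here, placing (3,4-dichlorophenyl)sulfanyl in place of 3,4-dichlorophenoxy on this aromatic carbon gives a 1.5-fold higher number from compound 1 to compound 4 (0.17 log units; within the scatter), the only direct reading in this set of a single change at this position. The step lies within the scatter, so the two compounds cannot be told apart: with the rest of the molecule held fixed, and with the heavy-atom, donor and acceptor counts of the group unchanged, exchanging the linking oxygen for sulfur produces no change that this read-out can resolve. No measurement of any property of these two groups bears on this result, so the numbers alone offer no explanation for it.

The compounds shown leave open whether a linking group differing more from these two, such as a sulfonyl or a methylene, would shift the number beyond the scatter at this position. They also do not show what happens when the linker stays and the ring changes, for example with fluorine in place of the two chlorines or a pyridine ring in place of the dichlorophenyl ring.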